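A few compounds are considered here, and "the series" means these few. Any claim that something is new, unique, unknown or untested is made for them only; others in the source may bear on it.

Measured so far:
- Compound 1 `COc1ccc(/C=C/C(=O)c2c(C)cc(O)c(C(=O)/C=C/c3ccc(OC)c(OC)c3)c2-c2ccccc2)cc1OC`: "not active" (no number reported)
- Compound 2 `Cc1cc(O)c(C(=O)/C=C/c2ccc(OCc3ccccc3)cc2)c(-c2ccc(Br)cc2)c1C(=O)/C=C/c1ccc(OCc2ccccc2)cc1`: 20000 nM
- Compound 3 `COc1ccc(/C=C/C(=O)c2c(C)cc(O)c(C(=O)/C=C/c3ccc(OC)cc3)c2-c2ccc(OCc3ccccc3)cc2)cc1`: 12000 nM

In a functional assay on MDA-MB-231 cells (Homo sapiens) for cytotoxicity, read by MTT assay, with a stated time of 24 h (a higher number here means a weaker inhibitor, a lower number a stronger inhibitor), compound 1 is recorded only as "not active" (no number reported), so no number stands against it. Compound 2 gives 20000 nM in this assay, and compound 3 gives 12000 nM; the two lie within the usual scatter of each other, and neither has a single-point step to compound 1. Compound 4 `COc1ccc(/C=C/C(=O)c2c(C)cc(O)c(C(=O)/C=C/c3ccc(OC)c(OC)c3)c2-c2ccc(OCc3ccccc3)cc2)cc1OC` is the next member: it differs from compound 1 by benzyloxy in place of hydrogen on an aromatic carbon. Within the data shown here, since compound 1 has no number, no size of step can be stated from it; the only guide is that compound 3, which carries the same benzyloxy-bearing aryl group, gives 12000 nM. Compound 4 is therefore expected to land in the same weak range, estimated at 15000 nM, with a range of 6000 nM to 50000 nM.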

Compound 4, half-maximal inhibitory concentration: 22000 nM
For compound 4 the middle estimate is 1.5-fold (0.17 log units) below the measured one, within the range that was stated.
By their numbers in this assay, from the lowest: compounds 3, 2 and 4 (each within the scatter of the next).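

Among these compounds, no step can be read for compound 4: compound 1, the one compound differing from it in one place, carries no number. As far as these compounds go, the size of any benzyloxy effect on the shared core stays open. No supporting measurement bears on this result.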